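The compounds below may be only part of what the source reports. "The series", "measured", "known", "first", "only" and "open" are said of these compounds alone.

In a functional assay (muscle tissue) with Cavia porcellus as the target (a lower number here means that less compound is needed, a higher number that more compound is needed for the effect), compound 1 `COC(=O)C1=C(C)N=C(C)/C(=C(\O)OC)C1c1cccc(OC)c1` gives 191 nM, which places it in the middle of the three measured numbers. Compound 3 `COC(=O)C1=C(C)N=C(C)/C(=C(\O)OC)C1c1ccccc1C#N` is lower at 15.9 nM, and compound 2 `COC(=O)C1=C(C)N=C(C)/C(=C(\O)OC)C1c1ccc(Cl)cc1` is higher at 8130 nM. Compound 4 `COC(=O)C1=C(C)N=C(C)/C(=C(\O)OC)C1c1cccc(C(F)(F)F)c1` keeps the core of compound 1 and changes one group: trifluoromethyl in place of methoxy on an aromatic carbon.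

Among the measured compounds shown here, no measured step makes this exact swap. The closest evidence is a 43-fold higher number from compound 1 to compound 2 (1.63 log units; beyond the scatter), with 4-chlorophenyl replacing 3-methoxyphenyl, and a 12-fold lower number from compound 1 to compound 3 (1.08 log units; beyond the scatter), with 2-cyanophenyl replacing 3-methoxyphenyl. Both steps are large, but they run in opposite directions, so they suggest no clear direction for compound 4. Those two steps replace the whole substituted phenyl group with a differently substituted one, whereas this change leaves the substituent on the same aromatic carbon. A much smaller step is therefore expected in this assay, probably none beyond the scatter. The estimate corresponds to a 1.6-fold lower number from compound 1 to compound 4 (0.20 log units; within the scatter). For compound 4 the estimated value is 120 nM, with an expected range from 25 nM to 600 nM.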

Compound 4, half-maximal effective concentration: 74.1 nM
For compound 4 the middle estimate is 1.6-fold (0.21 log units) above the measured one; the measured number falls inside the stated range.
By their numbers in this assay, from the lowest: compound 3; then compound 4; then compound 1; then compound 2.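

The earlier steps shown here changed both the substituent and where it sat on the phenyl ring, whereas this one changes only the group on a single aromatic carbon. In this assay, among the compounds shown here, trifluoromethyl in place of methoxy gives a 2.6-fold lower number from compound 1 to compound 4 (0.41 log units; beyond the scatter), so the group at this position alone moves the number, though only modestly compared with the earlier steps. This carbon therefore accepts a group with more heavy atoms and no hydrogen-bond acceptor without any rise in the number, but nothing available explains the drop.

The compounds shown leave open how an amine or a carboxylic acid on this same aromatic carbon would behave. They also do not show whether trifluoromethyl would give a similar step on another carbon of the ring.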